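The compounds below may be only part of what the source reports. "The series", "measured", "known", "first", "only" and "open" are said of these compounds alone.

Working notes on the series.

Compound 1 `Cc1c(OCCCCOc2ccc(C(=O)O)cc2)ccc(C(=O)CC(C)C)c1O` gives 2720 nM in an assay on HEK293 cells for positive allosteric modulation of metabotropic glutamate receptor 3 (Rattus norvegicus), read by thallium flux, with a stated time of 2.5 min; on this read-out lower numbers stand for an effect already at smaller amounts and higher numbers for an effect only at larger amounts of compound. Compound 2 `Cc1c(OCCCCOc2ccc(C(=O)O)cc2)ccc(C(=O)CC2CCCC2)c1O` gives only a limit, > 10000 nM, in this assay. The step of an at least 3.6-fold higher number from compound 1 to compound 2 (0.56 log units; beyond the scatter) is therefore read against the limit of > 10000 nM in this assay, at which 2 of the 3 values shown sit, and only its lower bound is known. Compound 3 `Cc1ccc(C(=O)O)cc1OCCCCOc1ccc(C(=O)CC2CCCC2)c(O)c1C` likewise gives only a limit, > 10000 nM, in this assay. The step that the two limits leave unreadable from compound 2 to compound 3 cannot be sized, since both ends sit at the limit (the limit of > 10000 nM in this assay, at which 2 of the 3 values shown sit). Compound 3 thus stands at the limit, with no number of its own.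

Compound 4 `Cc1ccc(C(=O)O)cc1OCCCCOc1ccc(C(=O)CC(C)C)c(O)c1C` differs from compound 3 by isopropyl in place of cyclopentyl on a saturated chain carbon bound to a carbonyl carbon. Among the compounds with values here, the only measured step that bears on this change is the reverse of an at least 3.6-fold higher number from compound 1 to compound 2 (0.56 log units; beyond the scatter), where cyclopentyl in place of isopropyl raised the number; going back from cyclopentyl to isopropyl is expected to lower it by a comparable amount, though the limit on compound 3 leaves the starting point unknown. The step of an at least 2.0-fold lower number from compound 3 to compound 4 (0.30 log units; that floor lies within the scatter) is expected to carry compound 4 back into the measurable range. Compound 4 is accordingly estimated at 5000 nM, within 2000 nM to 20000 nM, in this assay.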

Compound 4, half-maximal effective concentration: > 10000 nM
Compound 4 ended at the assay's limit (the forecaster's own chance of this, stated with the estimate: 40%); at least 2.0-fold (0.30 log units) between middle value and limit.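

Compound 4 gives only a limit, > 10000 nM, in this assay, so isopropyl on a saturated chain carbon bound to a carbonyl carbon does not by itself yield a number when 5-carboxy-2-methylphenyl sits on the oxygen. With isopropyl held constant, 5-carboxy-2-methylphenyl in place of 4-carboxyphenyl now has a readable size, an at least 3.6-fold higher number from compound 1 to compound 4 (0.56 log units; beyond the scatter), which the cyclopentyl pair could not give. The steps from compound 2 to compound 3 and from compound 3 to compound 4 cannot be read, since both ends of each are limits: the limit of > 10000 nM in this assay, at which 3 of the 4 values shown sit.

Within the data shown here, compound 1 remains the only compound with a number, so how far the other three lie past the limit stays open. Also open, from the compounds shown here alone, is whether a tetrazole in place of the carboxylic acid on the 5-carboxy-2-methylphenyl group would return a number.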